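This account rests on a few compounds, and the source may have more. Where it says the series, first, only, none or still open, it means among the compounds named here.

Measured so far in an ADME assay on HepG2 2.2.15 cells (Homo sapiens) for cytotoxicity, read by MTT assay, with stated times of 48 h and 9 days; on this read-out lower numbers stand for higher toxicity in this test and higher numbers for lower toxicity in this test:
Compound 1 `COc1ccc2c(=O)c(/C=C/C(=O)NCc3ccccc3)coc2c1` gives 376000 nM.
Compound 2 `COc1ccc2c(=O)c(/C=C/C(=O)Nc3ccccc3Cl)coc2c1` gives 1010000 nM.

Within the data shown here, on these two numbers compound 2 stands highest; its only neighbour is compound 1, with a 2.7-fold higher number from compound 1 to compound 2 (0.43 log units; beyond the scatter) between them. That step, a benzyl giving way to a 2-chlorophenyl on the amide-type nitrogen, is the only one measured in the series.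

Compound 3 `COc1cccc(NC(=O)/C=C/c2coc3cc(OC)ccc3c2=O)c1` differs from compound 2 by 3-methoxyphenyl in place of 2-chlorophenyl on an amide-type nitrogen. Among the measured compounds shown here, no measured step swaps one substituted aryl for another on this nitrogen; the single known step concerns benzyl against 2-chlorophenyl, so it bears on the present change only loosely. With nothing else to lean on, the expectation for this assay is a step from compound 2 to compound 3 no larger than the scatter, in no set direction, namely a 1.1-fold lower number from compound 2 to compound 3 (0.05 log units; within the scatter).

Compound 3 is therefore estimated at 900000 nM in this assay, with a range from 400000 nM to 2000000 nM.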

Compound 3, half-maximal cytotoxic concentration: 1130000 nM
For compound 3 the middle estimate is 1.3-fold (0.10 log units) below the measured one; the measured number falls inside the stated range.
By their numbers in this assay, from the lowest: compound 1; then compounds 2 and 3 (each within the scatter of the next).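

In this assay, the exchange of 2-chlorophenyl for 3-methoxyphenyl on the amide-type nitrogen gives a 1.1-fold higher number from compound 2 to compound 3 (0.05 log units; within the scatter), so this aryl-for-aryl change, which also brings in a hydrogen-bond acceptor, leaves the read-out within the scatter. The second comparison with benzyl, a 3.0-fold higher number from compound 1 to compound 3 (0.48 log units; beyond the scatter), places another directly attached substituted phenyl beyond the scatter from compound 1, and neither aryl compound goes against this pattern among these three compounds. Nothing available accounts for either step.

The two aryl groups differ in both substituent and ring placement, so these compounds do not separate those two changes. On these data alone, it remains open how this nitrogen would respond to an unsubstituted phenyl, a pyridine ring, a longer chain ending in phenyl or a carboxylic acid on the aryl ring.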